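The source may report more compounds than this note shows. Statements on the series, on what has been measured and on what is new or still open speak of the compounds shown alone.

Working notes on the series. Two compounds have numbers in a functional assay on HepG2 cells (Homo sapiens) for inhibition, read by MTT assay, with a stated time of 72 h (on this read-out lower numbers stand for stronger inhibition and higher numbers for weaker inhibition), so far. Compound 1 `CN(C(=O)NC(=O)c1ccc(F)c(F)c1)c1nc(C(F)(F)F)c(C(=O)N/N=C/c2ccccc2C(F)(F)F)s1` gives 10.4 ug/mL in this assay. Compound 2 `CN(C(=O)NC(=O)c1c(F)cccc1F)c1nc(C(F)(F)F)c(C(=O)N/N=C/c2ccc(C(F)(F)F)cc2)s1` gives 49.6 ug/mL in this assay, the higher of the two numbers, and the gap between compound 1 and compound 2 is beyond the scatter. For the measured compounds named here, no pair among the measured compounds differs in only one place, so no single-change step is available within the measured set.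

Compound 3 `CN(C(=O)NC(=O)c1c(F)cccc1F)c1nc(C(F)(F)F)c(C(=O)N/N=C/c2ccccc2C(F)(F)F)s1` has not yet been measured in this assay. It is built from compound 2 by one change (2-(trifluoromethyl)phenyl in place of 4-(trifluoromethyl)phenyl on a carbon with a double bond to nitrogen), the two having the same atoms joined differently. Going by the values given here, nothing measured isolates this change; the only guide is that compound 1, which also carries 2-(trifluoromethyl)phenyl on the carbon with a double bond to nitrogen, gives 10.4 ug/mL, whereas compound 2 gives 49.6 ug/mL. On that basis a step downward from compound 2 in this assay is expected, of moderate size, a 2.5-fold lower number from compound 2 to compound 3 (0.39 log units; beyond the scatter), with wide uncertainty because the compounds differ elsewhere too. Compound 3 is estimated at 20 ug/mL, within a range from 7 ug/mL to 55 ug/mL.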

Compound 3, half-maximal inhibitory concentration: 26.1 ug/mL
Compound 3: the middle estimate sits 1.3-fold (0.12 log units) below what was measured, within the range that was stated.
By their numbers in this assay, from the lowest: compound 1; then compounds 3 and 2 (each within the scatter of the next).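

With 2-(trifluoromethyl)phenyl in place of 4-(trifluoromethyl)phenyl on a carbon with a double bond to nitrogen, this assay gives a 1.9-fold lower number from compound 2 to compound 3 (0.28 log units; within the scatter) and so does not separate the two groups at this place. With 2,6-difluorophenyl in place of 3,4-difluorophenyl on a carbonyl carbon, the same assay gives a 2.5-fold higher number from compound 1 to compound 3 (0.40 log units; beyond the scatter) and this modest step is the one of the two single changes that reads beyond the scatter, whereas the first two compounds differed in both places at once and allowed neither change to be read alone. Nothing measured on these compounds offers a reason for either step.

Going by these compounds, whether the step on the carbonyl carbon holds when 4-(trifluoromethyl)phenyl stands on the carbon with a double bond to nitrogen stays open. The compounds shown also leave open how a methoxy group, a nitrile or a chlorine atom in place of trifluoromethyl on that phenyl ring would read, and how a morpholine or a carboxylic acid would read in place of the difluorophenyl group on the carbonyl carbon.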